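Cyano to Ethynyl on a Shared Amine Core

A few compounds are considered here, and "the series" means these few. Any claim that something is new, unique, unknown or untested is made for them only; others in the source may bear on it.

Compound 1 `N#CCN(Cc1ccccc1)Cc1ccc2ccccc2c1` was tested in an assay on HEK293 cells for binding affinity to Substance-K receptor (Rattus norvegicus), read by FRET, tested at 10 uM (a lower number here means less inhibition, a higher number more inhibition at the concentration tested (going by the name of the read-out)), where compound 1 gives 0%. A close relative, compound 2 `N#CCN(Cc1ccc(Br)cc1)Cc1ccc2ccccc2c1`, carries a bromo in place of hydrogen on an aromatic carbon, and in this assay compound 2 gives 0%. The step of no change at the digits printed from compound 1 to compound 2 (within the scatter) shows that this exchange made no difference within the scatter. Compound 1 therefore stands level with compound 2; neither shows measurable inhibition at the concentration tested.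

Compound 3 `C#CCN(Cc1ccccc1)Cc1ccc2ccccc2c1` has not yet been measured. It differs from compound 1 as follows: ethynyl in place of cyano on a saturated chain carbon bound to an amine nitrogen. For the measured compounds named here, the only measured step concerns a different part of the molecule and a different kind of exchange, so it does not speak directly to a cyano-to-ethynyl swap; what it does show is that the shared core itself gave no inhibition in either measured compound. With both compound 1 and compound 2 at no inhibition, a change confined to the cyanomethyl chain is expected to leave the read-out where it stands, giving an expected step of a number 2 percentage points higher from compound 1 to compound 3 (within the scatter) within the scatter. For compound 3 the expected value in this assay is 2%, with a range from -8% to 15%.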

Compound 3, a percentage reported as inhibition, at one concentration (the size of the read-out at that concentration, not a potency): 0%
Estimate against measurement, compound 3: 2 percentage points above, and the stated range covers the measured number.
By their numbers in this assay, from the lowest: compounds 1, 2 and 3 (each within the scatter of the next).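

In this assay the exchange of cyano for ethynyl on a saturated chain carbon bound to an amine nitrogen gives no change at the digits printed from compound 1 to compound 3 (within the scatter), so the cyanomethyl to propargyl change now adds a measured step at a second place on the molecule, apart from the earlier bromo exchange on the aromatic carbon. Taking out cyano also removes the one hydrogen-bond acceptor counted in that group, and the read-out at this single concentration does not register that difference; since the read-out shows no inhibition on either side of the step, it cannot tell whether the two groups are truly equivalent or whether neither compound reaches a level the assay can detect. Nothing measured here explains why the read-out stays the same.

Still open, as far as these compounds go, is whether any group at this place can move the read-out at all, as an amine, a carboxylic acid or a longer chain in place of cyano might. Also open, from the compounds shown here alone, is whether the shared core can give measurable inhibition when the benzyl ring carries something other than bromo, such as a methoxy group.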